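Swapping fluorines for chlorines on a benzyl ether

This account rests on a few compounds, and the source may have more. Where it says the series, first, only, none or still open, it means among the compounds named here.

Compound 1 `N[C@]1(C(=O)O)[C@H]2[C@@H](C[C@H]1OCc1ccccc1Cl)[C@]2(F)C(=O)O`: 4.99 nM
Compound 2 `N[C@]1(C(=O)O)[C@H]2[C@@H](C[C@H]1OCc1cccc(Cl)c1)[C@]2(F)C(=O)O`: 3.28 nM
Compound 3 `N[C@]1(C(=O)O)[C@H]2[C@@H](C[C@H]1OCc1cc(F)cc(F)c1)[C@]2(F)C(=O)O`: 12.4 nM

On an assay on CHO cells for binding affinity to metabotropic glutamate receptor 2 (Rattus norvegicus) (on this read-out higher numbers stand for weaker inhibition and lower numbers for stronger inhibition), compound 3 gives the highest number of the three: a 2.5-fold higher number from compound 1 to compound 3 (0.40 log units; beyond the scatter) and a 3.8-fold higher number from compound 2 to compound 3 (0.58 log units; beyond the scatter), whereas a 1.5-fold lower number from compound 1 to compound 2 (0.18 log units; within the scatter). Compound 4 `N[C@]1(C(=O)O)[C@H]2[C@@H](C[C@H]1OCc1cc(Cl)cc(Cl)c1)[C@]2(F)C(=O)O` keeps the same core and changes only the aryl group: 3,5-dichlorophenyl in place of 3,5-difluorophenyl on a saturated chain carbon bound to an oxygen on a saturated carbon. The step from compound 2 to compound 3 is the one that bears most on this change, since it trades a chlorine-bearing ring for a fluorine-bearing one and raised the number beyond the scatter; the step from compound 1 to compound 3 points the same way, though more weakly. Returning to chlorines is therefore expected to lower the number by a modest amount, a 2.1-fold lower number from compound 3 to compound 4 (0.32 log units; beyond the scatter), so compound 4 is estimated at 6 nM, within 2 nM to 18 nM.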

Compound 4, inhibition constant: 5.61 nM
The estimate for compound 4 lay 1.1-fold (0.03 log units) above the measured number; the measured number falls inside the stated range.
By their numbers in this assay, from the lowest: compounds 2, 1 and 4 (each within the scatter of the next); then compound 3.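

In this assay, putting chlorines back on the ring reverses the rise seen with 3,5-difluorophenyl (with a 2.2-fold lower number from compound 3 to compound 4 (0.34 log units; beyond the scatter)). The three chlorine-bearing rings cannot be told apart at this place, as both the added chloro group (with a 1.7-fold higher number from compound 2 to compound 4 (0.23 log units; within the scatter)) and the change from 2-chlorophenyl (with a 1.1-fold higher number from compound 1 to compound 4 (0.05 log units; within the scatter)) stay within the scatter, so only the fluorine-bearing ring stands apart. No measurement here gives a reason for this difference. The compounds shown leave open how a phenyl ring with a single fluorine would compare. They also leave open whether methyl groups in place of the halogens would match the chlorines.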